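A few compounds are considered here, and "the series" means these few. Any claim that something is new, unique, unknown or untested is made for them only; others in the source may bear on it.

In a functional assay on A549 cells (Homo sapiens) for cytotoxicity, read by MTT assay, with a stated time of 72 h (on this read-out lower numbers stand for stronger inhibition and higher numbers for weaker inhibition), compound 1 `Cc1ccc(-n2nc(C(=O)Nc3ccc(Oc4ncnc5ccsc45)c(F)c3)c(C)cc2=O)cc1` gives 5890 nM. Compound 2 `Cc1cc(=O)n(-c2ccc(Br)cc2F)nc1C(=O)Nc1ccc(Oc2ncnc3sccc23)c(F)c1` in this assay gives 11500 nM, a number that the usual scatter cannot separate from that of compound 1. Compound 3 `Cc1ccc(-n2nc(C(=O)Nc3ccc(Oc4ncnc5sccc45)c(F)c3)c(C)cc2=O)cc1` differs from compound 2 in one place: 4-methylphenyl in place of 4-bromo-2-fluorophenyl on an aromatic nitrogen. Within the data shown here, no measured pair shows this change on its own, so nothing here tells how large a step to expect; with only compound 1 and compound 2 in hand, the step is expected to stay within the scatter. Compound 3 in this assay is therefore estimated at 6500 nM, within 2500 nM to 16000 nM, an expected step of a 1.8-fold lower number from compound 2 to compound 3 (0.25 log units; within the scatter).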

Compound 3, half-maximal inhibitory concentration: > 40000 nM
Compound 3: a limit, no number; the forecaster's own chance of this, stated with the estimate: 5%; at least 6.1-fold (0.78 log units) between middle value and limit.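

In this assay, 4-methylphenyl in place of 4-bromo-2-fluorophenyl on the aromatic nitrogen gives an at least 3.4-fold higher number from compound 2 to compound 3 (0.54 log units; beyond the scatter), so this position responds to the change in a way that compound 1 and compound 2 alone could not show. Exchanging the group on the oxygen for another with the same atom counts gives an at least 6.7-fold higher number from compound 1 to compound 3 (0.83 log units; beyond the scatter), so that group counts as well. Compound 3 gives a limit, not a number: the limit of > 40000 nM in this assay, at which 1 of the 3 values shown sits.

Going by these compounds, the full size of both steps stays open. On these data alone, it also stays open whether the bromine or the fluorine accounts for the step, and how a plain phenyl or a 4-aminophenyl would read at this position.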